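The compounds below may be only part of what the source reports. "The series", "measured", "known", "first", "only" and "open" are said of these compounds alone.

Of the compounds shown here, three sharing one core have been measured in a physicochemical assay for lipophilicity, measured as octanol-water partition, at pH 7.4; a lower number here means a more polar compound, a higher number a more lipophilic compound. Compound 1 `CCCCOc1ccc(NC(=N)Nc2ccc(CCCCO)cc2)cc1` gives 1.72, compound 2 `CCc1ccc(NC(=N)Nc2ccc(CC)cc2)cc1` gives 1.7, and compound 3 `N=C(Nc1ccc(-c2ccccc2)cc1)Nc1ccc(-c2ccccc2)cc1` gives 3.13. Within this small set compound 1 sits second highest of the three numbers: its value and that of compound 2 lie within the scatter of each other, so nothing separates them, whereas compound 3 stands clearly higher, beyond the scatter.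

Compound 4 `CCCCOc1ccc(NC(=N)Nc2ccc(OCCCC)cc2)cc1` has not yet been measured in this assay. It has the same atoms as compound 1, joined differently:

butoxy in place of 4-hydroxybutyl on an aromatic carbon

For the measured compounds named here, no measured pair in the set shows this exact change, so the size of the step can only be expected, not read off. The 4-hydroxybutyl group that leaves carries a hydrogen-bond donor; the butoxy that enters carries none. On that basis, the step from compound 1 to compound 4 is estimated to be upward and beyond the scatter, at a number 1.08 log units higher from compound 1 to compound 4 (beyond the scatter). Compound 4 is expected to give about 2.8, somewhere between 2.2 and 3.4.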

Compound 4, distribution coefficient: 3.52
The estimate for compound 4 lay 0.72 log units below the measured number; measured number above the stated range.
By their numbers in this assay, from the lowest: compounds 2 and 1 (each within the scatter of the next); then compound 3; then compound 4.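

For the compounds shown here, this is the first change at a single place in the set, and it shows that this place matters in this assay: putting butoxy in place of 4-hydroxybutyl on an aromatic carbon, para to a large group, gives a number 1.80 log units higher from compound 1 to compound 4 (beyond the scatter). The step is large even though both groups have 5 heavy atoms (4 carbon, 1 oxygen) and 1 hydrogen-bond acceptor; what differs is how those atoms are joined, with 1 hydrogen-bond donor in the group that leaves and 0 in the group that enters. Nothing measured here explains why the step has this size.

Going by these compounds alone, the single step changes the attachment of the oxygen and removes the hydroxyl hydrogen together, so their shares cannot be told apart. From the compounds shown here alone, a plain butyl, a 4-aminobutyl or a longer alkoxy chain at this place remains open.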